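The source may hold more compounds than are shown below. What is called first, only, known or untested is meant among the compounds shown, and "the series" means these compounds.

Values so far in a functional assay on A549 cells (Homo sapiens) for antiproliferative activity, read by MTT assay, with a stated time of 72 h; on this read-out lower numbers stand for stronger inhibition and higher numbers for weaker inhibition
compound 1 `Nc1nc(N)c2cc(CSC(=S)N3CCN(C4CCCCC4)CC3)ccc2n1`: 4710 nM
compound 2 `Nc1nc(N)c2cc(CSC(=S)N3CCN(c4ccccc4)CC3)ccc2n1`: 2970 nM
compound 3 `Cc1ccc(N2CCN(C(=S)SCc3ccc4nc(N)nc(N)c4c3)CC2)cc1`: 2190 nM

Compound 3 sits at the low end of this small set, but only one gap is beyond the scatter, and it is modest: a 2.2-fold lower number from compound 1 to compound 3 (0.33 log units; beyond the scatter). The other gap to compound 3 stays within the scatter: a 1.4-fold lower number from compound 2 to compound 3 (0.13 log units; within the scatter). Those two compounds therefore cannot be separated.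

Compound 4 `Cc1ccc(N2CCN(C(=S)SCc3ccc4nc(N)nc(N)c4c3)CC2)c(C)c1` turns 4-methylphenyl into 2,4-dimethylphenyl, with methyl in place of hydrogen on an aromatic carbon, ortho to a large group and meta to a methyl group (methyl in place of hydrogen on an aromatic carbon). Going by the values given here, the closest precedent is the same kind of change on the phenyl ring, a 1.4-fold lower number from compound 2 to compound 3 (0.13 log units; within the scatter). The wider swap on that nitrogen moved the number little too, a 1.6-fold lower number from compound 1 to compound 2 (0.20 log units; within the scatter). Among the compounds with values here, no measured compound carries a group at the new place, so the range stays wide.

No step beyond the scatter is expected, and the estimated step is a 1.1-fold lower number from compound 3 to compound 4 (0.04 log units; within the scatter). For compound 4 the estimated value is 2000 nM with an expected range from 900 nM to 4500 nM.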

Compound 4, half-maximal inhibitory concentration: 3000 nM
Estimate against measurement, compound 4: 1.5-fold (0.18 log units) below; low and high end bracket the measured number.
By their numbers in this assay, from the lowest: compounds 3, 2, 4 and 1 (each within the scatter of the next, the first and the last beyond it).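

In this assay, a methyl on the aromatic carbon ortho to a large group gives a 1.4-fold higher number from compound 3 to compound 4 (0.14 log units; within the scatter), so this first group at the new place does not separate the two compounds. Set against the other nitrogen substituents, 2,4-dimethylphenyl gives a 1.0-fold higher number from compound 2 to compound 4 (0.00 log units; within the scatter) and a 1.6-fold lower number from compound 1 to compound 4 (0.20 log units; within the scatter), which leaves the gap between compound 1 and compound 3 as the only one beyond the scatter. Nothing measured here bears on why these steps stay small.

From the compounds shown here alone, whether a methoxy group, an amine or a carboxylic acid at this place would give a step beyond the scatter remains open. Also open, going by these compounds, is how 2-methylphenyl, without the methyl of the 4-methylphenyl group, would read on this scale.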